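Swapping the triazole for an oxazole on the thiazole series

The compounds below may be only part of what the source reports. "The series", "measured", "known", "first", "only" and "open" are said of these compounds alone.

The study opens with compound 1 `Cc1cc(Cl)ccc1-c1cccc(COc2ccc([C@H](CC(=O)O)c3ncnn3C)cc2)c1`, which in a functional assay on A9 cells for agonist activity at Free fatty acid receptor 1 (Homo sapiens), read by inositol phosphate accumulation (a lower number here means that less compound is needed, a higher number that more compound is needed for the effect), gives 11 nM. Compound 2 `Cc1nc(-c2ccc(C(F)(F)F)cc2)sc1COc1ccc([C@H](CC(=O)O)c2ncnn2C)cc1` shares the acid-bearing side chain but carries a different biaryl ether half; in this assay compound 2 gives "not determined" (no result reported), so it stands nowhere on the scale. Compound 3 `Cc1nc(-c2ccc(C(F)(F)F)cc2)sc1COc1ccc([C@H](CC(=O)O)c2cnco2)cc1` differs from compound 2 only in one place: 1,3-oxazol-5-yl in place of 1-methyl-1H-1,2,4-triazol-5-yl on a saturated chain carbon bound to an aromatic carbon and a saturated chain carbon. For the measured compounds named here, with no measured step to lean on, a modest shift in this assay, if any, is expected, more likely toward a higher number than a lower one. Compound 3 is therefore estimated at 25 nM, with a plausible range from 6 nM to 100 nM.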

Compound 3, half-maximal effective concentration: 9 nM
Compound 3: the middle estimate sits 2.8-fold (0.44 log units) above what was measured; measured number inside the range.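

For the compounds shown here, compound 2 has no single number in this assay, so no step from it to compound 3 can be read. What replacing 1-methyl-1H-1,2,4-triazol-5-yl with 1,3-oxazol-5-yl does to the value stays open, and nothing shown bears on compound 3's result.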